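Nitro on the phenyl ring of compound 1: an expectation

The source may report more compounds than this note shows. Statements on the series, on what has been measured and on what is new or still open speak of the compounds shown alone.

Compound 1 `O=C1Nc2ccc(Cl)cc2/C1=N/NC(=S)N1CCN(c2ccccc2)CC1` gives 7340 nM in a functional assay on A549 cells (Homo sapiens) for inhibition, read by MTT assay, with a stated time of 72 h (a lower number here means a stronger inhibitor, a higher number a weaker inhibitor), the lowest of the three numbers measured. Compound 2 `O=C1Nc2ccc([N+](=O)[O-])cc2/C1=N/NC(=S)N1CCN(c2ccccc2)CC1` gives 17900 nM and compound 3 `O=C1Nc2cc(Cl)ccc2/C1=N/NC(=S)N1CCN(c2ccccc2)CC1` gives 27700 nM. Compound 4 `O=C1Nc2ccc(Cl)cc2/C1=N/NC(=S)N1CCN(c2ccccc2[N+](=O)[O-])CC1` differs from compound 1 by nitro in place of hydrogen on an aromatic carbon. For the measured compounds named here, the one measured step of a single change, a 2.4-fold higher number from compound 1 to compound 2 (0.39 log units; beyond the scatter), concerns nitro in place of chloro on the shared core, not the phenyl ring, so it bears on compound 4 only loosely. Going by the values given here, no measured step touches the phenyl ring. Compound 4 is therefore expected to stay near compound 1, with a step of a 1.3-fold higher number from compound 1 to compound 4 (0.11 log units; within the scatter) or none beyond the scatter. For compound 4 the estimate is 9500 nM, within 3500 nM to 26000 nM.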

Compound 4, half-maximal inhibitory concentration: 5580 nM
The estimate for compound 4 lay 1.7-fold (0.23 log units) above the measured number; the range from low to high includes it.
By their numbers in this assay, from the lowest: compounds 4 and 1 (each within the scatter of the next); then compounds 2 and 3 (each within the scatter of the next).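

Phenyl to 2-nitrophenyl is the first change on this ring with a measured result, and in this assay it reads a 1.3-fold lower number from compound 1 to compound 4 (0.12 log units; within the scatter). At this position, ortho to a large group, nitro therefore brings no step beyond the scatter, whereas nitro in place of chloro on the shared core gave a 2.4-fold higher number from compound 1 to compound 2 (0.39 log units; beyond the scatter). Nothing measured here offers a reason for this result.

On these data alone, whether an amine or a carboxylic acid at the same position would also stay within the scatter of compound 1 remains open.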